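The source may hold more compounds than are shown below. What is called first, only, known or untested is meant among the compounds shown, and "the series" means these compounds.

Compound 1 `O=C(CSc1ncccn1)N1N=C(c2cc3ccccc3oc2=O)C[C@@H]1c1ccc(C(F)(F)F)cc1`: 4750 nM
Compound 2 `O=C(CSCc1ccco1)N1N=C(c2cc3ccccc3oc2=O)C[C@@H]1c1ccc(C(F)(F)F)cc1`: 11200 nM

Both values come from a functional assay on HepG2 cells (Homo sapiens) for cytotoxicity, read by MTT assay, with a stated time of 48 h; a higher number here means a weaker inhibitor, a lower number a stronger inhibitor. Compound 2 stands highest of the two, at 11200 nM, which makes it the weaker inhibitor of the pair. Compound 3 `O=C(CSc1ccc([N+](=O)[O-])cc1)N1N=C(c2cc3ccccc3oc2=O)C[C@@H]1c1ccc(C(F)(F)F)cc1` differs from it at the sulfur: 4-nitrophenyl in place of (furan-2-yl)methyl on a sulfur. Among the compounds with values here, only one measured step bears on this change, a 2.4-fold higher number from compound 1 to compound 2 (0.37 log units; beyond the scatter). That modest step altered the same sulfur substituent, with (furan-2-yl)methyl in place of pyrimidin-2-yl. Compound 3 also lacks the (furan-2-yl)methyl and, like compound 1, carries an aromatic ring on the sulfur. Within the data shown here, a modest move towards a lower number is therefore expected, though no measured compound carries 4-nitrophenyl, so this remains uncertain. The expected change is a 1.9-fold lower number from compound 2 to compound 3 (0.27 log units; within the scatter). Compound 3 is estimated at 6000 nM, with an expected range of 2500 nM to 14000 nM.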

Compound 3, half-maximal inhibitory concentration: 7760 nM
The estimate for compound 3 lay 1.3-fold (0.11 log units) below the measured number; the measured number falls inside the stated range.
By their numbers in this assay, from the lowest: compounds 1, 3 and 2 (each within the scatter of the next, the first and the last beyond it).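

In this assay the exchange on the sulfur gives a 1.4-fold lower number from compound 2 to compound 3 (0.16 log units; within the scatter) and, measured against the pyrimidin-2-yl group, a 1.6-fold higher number from compound 1 to compound 3 (0.21 log units; within the scatter) so compound 3 cannot be separated from either neighbour, even though those two differ beyond the scatter. At this position, then, 4-nitrophenyl, with its six-membered aromatic ring of carbon only and more heavy atoms than (furan-2-yl)methyl, produces no step beyond the scatter from either earlier sulfur substituent. No supporting measurement accounts for these numbers.

The compounds shown leave open how an unsubstituted phenyl, a benzyl group or a chain ending in an amine or a carboxylic acid on this sulfur would read. They also leave open whether the small steps seen here would hold if the trifluoromethyl group elsewhere on the shared core were replaced by a methoxy group.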